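Nitro in place of dimethylamino on an aryl semicarbazone

The compounds below may be only part of what the source reports. "The series", "measured", "known", "first", "only" and "open" are said of these compounds alone.

Measured so far:
compound 1, `COc1cc(/C=N/NC(=O)Nc2cccc3ccccc23)ccc1O`, 300 mg/kg
compound 2, `CN(C)c1ccc(/C=N/NC(=O)Nc2cccc3ccccc23)cc1`, 100 mg/kg
compound 3, `O=C(N/N=C/c1ccc(Cl)cc1Cl)Nc1cccc2ccccc12`, 100 mg/kg

All three were tested in a functional assay on the whole organism (strain Swiss albino) with Mus musculus as the target, in the maximal electroshock model, with a stated time of 0.5 h; on this read-out higher numbers stand for an effect only at larger amounts of compound and lower numbers for an effect already at smaller amounts. Compound 2 gives 100 mg/kg, the same number as compound 3 within the scatter, and together these two show the lowest numbers of the three; compound 1 gives a higher number, beyond the scatter.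

Compound 4, `O=C(N/N=C/c1ccc([N+](=O)[O-])cc1)Nc1cccc2ccccc12`, has not yet been measured. Its difference from compound 2 is nitro in place of dimethylamino on an aromatic carbon. Going by the values given here, no pair of measured compounds differs in only one place, so nothing here shows what such a swap does. The change keeps the group count and position, so the expected step of no change at the digits printed from compound 2 to compound 4 (within the scatter) is none beyond the scatter. Compound 4 is therefore expected to give about 100 mg/kg, between 30 mg/kg and 300 mg/kg.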

Compound 4, minimum effective dose: 300 mg/kg
Compound 4: middle estimate off by 3.0-fold (0.48 log units), on the low side, within the range that was stated.
By their numbers in this assay, from the lowest: compounds 2 and 3 (each within the scatter of the next); then compounds 1 and 4 (each within the scatter of the next).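

In this assay, nitro in place of dimethylamino on an aromatic carbon gives a 3.0-fold higher number from compound 2 to compound 4 (0.48 log units; beyond the scatter). This first single-place comparison shows that the group at this position matters, even though both groups have the same count of heavy atoms and neither carries a net charge. Nothing measured here explains the step.

On these data alone, it remains open whether a simple amino group, a methoxy group or a single chlorine at this position would match compound 2 or compound 4. One step also cannot show whether this swap would act alike on another core.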